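The compounds below may be only part of what the source reports. "The series", "measured", "known", "first", "only" and "open" are said of these compounds alone.

Of the compounds shown here, two have numbers so far. In a functional assay on a cell-free system (plasma, Homo sapiens) for inhibition, with Plasma (Rattus norvegicus) as the target (a lower number here means a stronger inhibitor, a higher number a weaker inhibitor), compound 1 `Cc1c(OCc2ccccc2)ccc2c(N3CCNCC3)cc(=O)oc12` gives 1100 nM, and compound 2 `O=c1cc(N2CCNCC2)c2cc(OCc3cccnc3)ccc2o1` gives 36000 nM. Compound 1 therefore holds the lower of the two numbers, and the gap between them lies beyond the scatter. The two compounds differ in more than one place, so this gap cannot be tied to any single group.

Compound 3 `CSCCOc1ccc2c(N3CCNCC3)cc(=O)oc2c1C` keeps the core of compound 1 and changes one group: (methylsulfanyl)methyl in place of phenyl on a saturated chain carbon bound to an oxygen on an aromatic ring. The same change reads as benzyloxy to 2-(methylsulfanyl)ethoxy.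

Within the data shown here, no measured pair isolates this change, so the expectation is weakly grounded and the range is kept wide. Among the measured compounds shown here, the starting point is compound 1 at 1100 nM, the better of only two numbers, so a move towards weaker inhibition in this assay seems more likely than a gain. The expected step is moderate, a 4.5-fold higher number from compound 1 to compound 3 (0.66 log units; beyond the scatter), and is estimated to lie just beyond the scatter. For compound 3 the estimated value is 5000 nM, with an expected range of 1500 nM to 17000 nM.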

Compound 3, half-maximal inhibitory concentration: 1500 nM
Beside the measured number, compound 3's estimate is 3.3-fold (0.52 log units) above it; low and high end bracket the measured number.
By their numbers in this assay, from the lowest: compounds 1 and 3 (each within the scatter of the next); then compound 2.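

Placing 2-(methylsulfanyl)ethoxy where compound 1 carries benzyloxy gives, in this assay, a 1.4-fold higher number from compound 1 to compound 3 (0.13 log units; within the scatter) and leaves the two compounds indistinguishable in this assay. Among these compounds, this is the first comparison that differs in one place, and it shows that at this saturated chain carbon bound to an oxygen on an aromatic ring, the phenyl group is not required to keep the number at this level: a ringless (methylsulfanyl)methyl group, with fewer heavy atoms and a sulfur, serves equally well within the scatter. Nothing measured here offers a reason for this result.

The compounds shown do not tell how a 2-methoxyethoxy group, a plain propoxy chain, or a chain ending in an amine or a carboxylic acid would read in this assay at this place, so the role of the sulfur stays open. Compound 2 at 36000 nM differs from compound 1 and from compound 3 in more than one place, so its number cannot yet be tied to any single group.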